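From trifluoromethoxy to methoxymethyl on the way to compound 4

The source may report more compounds than this note shows. Statements on the series, on what has been measured and on what is new or still open speak of the compounds shown alone.

Of the compounds shown here, three sharing one core have been measured in a functional assay for agonist activity at G protein-coupled receptor 88 (Homo sapiens), read by HTRF and cAMP accumulation; on this read-out lower numbers stand for an effect already at smaller amounts and higher numbers for an effect only at larger amounts of compound. Compound 1 `CC[C@H](C)[C@H](N)CN(C(=O)[C@@H]1C[C@H]1c1ccccc1)c1ccc(-c2ccc(OC(C)C)cc2)cc1` gives 72 nM, compound 2 `CC[C@H](C)[C@H](N)CN(C(=O)[C@@H]1C[C@H]1c1ccccc1)c1ccc(-c2ccc(Oc3ccccc3)cc2)cc1` gives 94 nM, and compound 3 `CC[C@H](C)[C@H](N)CN(C(=O)[C@@H]1C[C@H]1c1ccccc1)c1ccc(-c2ccc(OC(F)(F)F)cc2)cc1` gives 170 nM. Compound 3 thus carries the highest of the three numbers: the step of a 2.4-fold higher number from compound 1 to compound 3 (0.37 log units; beyond the scatter) lies beyond the scatter, whereas a 1.8-fold higher number from compound 2 to compound 3 (0.26 log units; within the scatter) stays within it, and a 1.3-fold higher number from compound 1 to compound 2 (0.12 log units; within the scatter) is likewise within the scatter.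

Compound 4 `CC[C@H](C)[C@H](N)CN(C(=O)[C@@H]1C[C@H]1c1ccccc1)c1ccc(-c2ccc(COC)cc2)cc1` is not yet measured. It differs from compound 3 by methoxymethyl in place of trifluoromethoxy on an aromatic carbon. Going by the values given here, no measured step introduces a methoxymethyl group, so nothing bears directly on this change. The two steps that touch the same position, a 2.4-fold higher number from compound 1 to compound 3 (0.37 log units; beyond the scatter) and a 1.8-fold higher number from compound 2 to compound 3 (0.26 log units; within the scatter), show that the group on this aromatic carbon shifts the read-out in this assay by at most a modest amount, with trifluoromethoxy at the high end. Compound 4 is therefore expected to land near or somewhat below compound 3, the estimated step being a 1.5-fold lower number from compound 3 to compound 4 (0.19 log units; within the scatter). The estimate for compound 4 in this assay is 110 nM, within a range from 45 nM to 280 nM.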

Compound 4, half-maximal effective concentration: 35 nM
Compound 4: middle estimate off by 3.1-fold (0.50 log units), on the high side; measured number below the stated range.
By their numbers in this assay, from the lowest: compound 4; then compounds 1, 2 and 3 (each within the scatter of the next, the first and the last beyond it).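

In this assay, methoxymethyl on this aromatic carbon, para to a large group, gives the lowest number of the four compounds, with a 4.9-fold lower number from compound 3 to compound 4 (0.69 log units; beyond the scatter), a 2.7-fold lower number from compound 2 to compound 4 (0.43 log units; beyond the scatter) and a 2.1-fold lower number from compound 1 to compound 4 (0.31 log units; beyond the scatter). Compounds 1, 2 and 3 all have an oxygen attached directly to the ring, whereas compound 4 has a carbon there, and this change shows that the position can lower the number beyond the scatter from every earlier group. Nothing given here accounts for the drop.

Going by these compounds, it remains open whether the ring-bound carbon or the oxygen further out in the chain matters more; an ethyl chain, a hydroxymethyl group or a methoxyethyl group could separate the two. On these data alone, whether the step carries over to other groups on the shared core also remains open.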